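This account rests on a few compounds, and the source may have more. Where it says the series, first, only, none or still open, it means among the compounds named here.

Compound 1 `CCCC[C@]1(CC)CS(=O)(=O)c2ccc(Br)cc2[C@@H](c2cccc(OC)c2)[C@H]1O`: 70 nM
Compound 2 `CCCC[C@]1(CC)CS(=O)(=O)c2ccc(N(O)C(=O)OC(C)(C)C)cc2[C@@H](c2ccccc2)[C@H]1O`: 2670 nM
Compound 3 `CCCCCC1(CCCCC)CS(=O)(=O)c2ccc(C)cc2[C@@H](c2ccc(F)cc2)[C@H]1O`: 318 nM

All three were tested in an assay on cells for inhibition of ileal sodium/bile acid cotransporter (Homo sapiens); a lower number here means a stronger inhibitor, a higher number a weaker inhibitor. Compound 2 gives the highest number of the three, standing beyond the scatter above compound 3 and further still above compound 1. Compound 4 `CCCC[C@]1(CC)CS(=O)(=O)c2ccc([N+](C)(C)C)cc2[C@@H](c2ccccc2)[C@H]1O` has not yet been measured in this assay. It differs from compound 2 in one place: a group of 4 heavy atoms (3 carbon, 1 nitrogen; no ring) in place of a group of 9 heavy atoms (5 carbon, 1 nitrogen, 3 oxygen; no ring), on an aromatic carbon. Among the compounds with values here, no measured pair shows exactly this change, so the size of the step is open. Replacing the larger neutral group by a small group of net charge +1 is expected to lower the number by a moderate amount, beyond the scatter. Compound 4 is therefore estimated at 800 nM, within a range from 150 nM to 4000 nM. The expected step is a 3.3-fold lower number from compound 2 to compound 4 (0.52 log units; beyond the scatter).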

Compound 4, half-maximal inhibitory concentration: 83 nM
Compound 4: the middle estimate sits 9.6-fold (0.98 log units) above what was measured, and the stated range ends above it.
By their numbers in this assay, from the lowest: compounds 1 and 4 (each within the scatter of the next); then compound 3; then compound 2.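

Replacing the hydroxy(tert-butoxycarbonyl)amino group with the smaller group of net charge +1 on this aromatic carbon gives a 32-fold lower number from compound 2 to compound 4 (1.51 log units; beyond the scatter) in this assay and counts as a large step. Within the data shown here, what sits at this position therefore matters strongly, and a charged group is tolerated here, which the earlier compounds, none of them charged, could not show. Nothing available explains the size of this step.

Charge and size change together in this step, so their contributions remain unseparated. A tert-butyl group or a dimethylamino group on the same carbon of compound 4 would help to tell them apart.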